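Shortening the ethoxy group of compound 3 to methoxy

This account rests on a few compounds, and the source may have more. Where it says the series, first, only, none or still open, it means among the compounds named here.

Three compounds sharing one core have numbers in a functional assay on A549 cells (Homo sapiens) for cytotoxicity, read by MTT assay; a lower number here means a stronger inhibitor, a higher number a weaker inhibitor. Compound 1 `C=C1C(=O)[C@]23C[C@@]1(O)CC[C@H]2[C@@]12C=CC(=O)[C@](C)(C(=O)O1)[C@H]2[C@@H]3C(=O)OC` gives 90900 nM, compound 2 `C=C1C(=O)[C@]23C[C@@]1(I)CC[C@H]2[C@@]12C=CC(=O)[C@](C)(C(=O)O1)[C@H]2[C@@H]3C(=O)OC` gives 53200 nM and compound 3 `C=C1C(=O)[C@]23C[C@@]1(OCC)CC[C@H]2[C@@]12C=CC(=O)[C@](C)(C(=O)O1)[C@H]2[C@@H]3C(=O)OC` gives 18200 nM. Compound 3 has the lowest of the three numbers, and its gaps to the other two lie beyond the scatter.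

The next compound is compound 4 `C=C1C(=O)[C@]23C[C@@]1(OC)CC[C@H]2[C@@]12C=CC(=O)[C@](C)(C(=O)O1)[C@H]2[C@@H]3C(=O)OC`, with the change hydrogen in place of methyl on a saturated chain carbon bound to an oxygen on a saturated carbon, so ethoxy becomes methoxy.

Going by the values given here, the closest precedent is the step made on that same oxygen, a 5.0-fold lower number from compound 1 to compound 3 (0.70 log units; beyond the scatter). The step of a 2.9-fold lower number from compound 2 to compound 3 (0.47 log units; beyond the scatter) bears on it less directly, since it exchanges a whole group, and a 1.7-fold lower number from compound 1 to compound 2 (0.23 log units; within the scatter) does not touch the oxygen substituent at all. Among the compounds with values here, no measured pair isolates a methyl-to-ethyl change, so the inference is limited. Methoxy stands between hydroxy and ethoxy by chain length, which suggests a modest move back towards compound 1 while most of the lower number is retained. The expected step is a 1.6-fold higher number from compound 3 to compound 4 (0.22 log units; within the scatter), which is not expected to exceed the scatter clearly. The estimate for compound 4 is 30000 nM, with an expected range of 14000 nM to 65000 nM.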

Compound 4, half-maximal inhibitory concentration: 54500 nM
Compound 4: the middle estimate sits 1.8-fold (0.26 log units) below what was measured; measured number inside the range.
By their numbers in this assay, from the lowest: compound 3; then compounds 2, 4 and 1 (each within the scatter of the next).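

In this assay, taking the methyl off the ethoxy group gives a 3.0-fold higher number from compound 3 to compound 4 (0.48 log units; beyond the scatter) and shows that the lower number of compound 3 is not shared by every alkyl ether at this oxygen: the ethyl group holds it, while the methyl group does not. The two remaining new steps, a 1.7-fold lower number from compound 1 to compound 4 (0.22 log units; within the scatter) and a 1.0-fold higher number from compound 2 to compound 4 (0.01 log units; within the scatter), both lie within the scatter, so methoxy cannot be told apart from hydroxy or iodo, and compound 3 alone stands beyond the scatter from the other three compounds. The data at hand offer nothing that accounts for the difference made by this single methyl group.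

As far as these compounds go, with only methoxy and ethoxy as ethers, one step of chain length cannot establish a trend, and it remains open whether a longer chain such as propyl or butyl would extend the lower number of compound 3 or lose it. From the compounds shown here alone, it is also open whether the effect belongs to the ether oxygen or to the chain alone, which a direct comparison of ethoxy with an ethylamine or a plain propyl group would begin to separate.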